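Butylsulfonamide versus difluorophenylsulfonamide in a quinazoline series

The source may report more compounds than this note shows. Statements on the series, on what has been measured and on what is new or still open speak of the compounds shown alone.

Measured compounds:
compound 1 `CCCCS(=O)(=O)Nc1cc(-c2ccc3ncnc(NCCN(C)C)c3c2)cnc1OC` gives 280 nM in a functional assay on MDA-MB-231 cells (Homo sapiens) for antiproliferative activity, read by sulforhodamine B assay, with a stated time of 72 h; on this read-out lower numbers stand for stronger inhibition and higher numbers for weaker inhibition
compound 2 `COc1ncc(-c2ccc3ncnc(NCCN(C)C)c3c2)cc1NS(=O)(=O)c1ccc(F)cc1F` gives 710 nM
compound 3 `COc1ncc(-c2ccc3ncnc(NCCCN(C)C)c3c2)cc1NS(=O)(=O)c1ccc(F)cc1F` gives 1540 nM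

Compound 4 `CCCCS(=O)(=O)Nc1cc(-c2ccc3ncnc(NCCCN(C)C)c3c2)cnc1OC` is not yet measured. The cores of compound 3 and compound 2 differ by (dimethylamino)methyl in place of dimethylamino on a saturated chain carbon, two bonds along the chain from a nitrogen on an aromatic ring, a change that gave a 2.2-fold higher number from compound 2 to compound 3 (0.34 log units; beyond the scatter). On the core of compound 2 the sulfonyl substituent was already varied: butyl in place of 2,4-difluorophenyl on a sulfonyl sulfur gave a 2.5-fold lower number from compound 2 to compound 1 (0.40 log units; beyond the scatter). Compound 4 carries the same change on the core of compound 3: butyl in place of 2,4-difluorophenyl on a sulfonyl sulfur, at a place described in the same words. For the measured compounds named here, the expectation for compound 4 rests on the single earlier step, because a 2.5-fold lower number from compound 2 to compound 1 (0.40 log units; beyond the scatter) is the only precedent, so a step of about the same size is estimated, a 2.5-fold lower number from compound 3 to compound 4 (0.40 log units; beyond the scatter). On that basis compound 4 is expected to give about 620 nM, between 300 nM and 1300 nM, in this assay.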

Compound 4, half-maximal inhibitory concentration: 880 nM
Compound 4: the middle estimate sits 1.4-fold (0.15 log units) below what was measured; measured number inside the range.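

In this assay, butyl in place of 2,4-difluorophenyl on a sulfonyl sulfur gives a 1.8-fold lower number from compound 3 to compound 4 (0.24 log units; within the scatter), so on this core the step alone is not resolved, yet it does not differ from the earlier step: the same change on two cores in this assay, a 2.5-fold lower number (0.40 log units; beyond the scatter) from compound 2 to compound 1 and a 1.8-fold lower number (0.24 log units; within the scatter) from compound 3 to compound 4, 1.4-fold (0.16 log units) apart, within the scatter of two such steps

The (dimethylamino)methyl in place of dimethylamino change gives a 3.1-fold higher number from compound 1 to compound 4 (0.50 log units; beyond the scatter), and it also carries from one core to the other: the same change on two cores in this assay, a 2.2-fold higher number (0.34 log units; beyond the scatter) from compound 2 to compound 3 and a 3.1-fold higher number (0.50 log units; beyond the scatter) from compound 1 to compound 4, 1.4-fold (0.16 log units) apart, within the scatter of two such steps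

These four compounds show that each change keeps its size across this one pair of cores, but they do not show that this holds for other cores or give any reason for the steps.

Going by these compounds, it remains open whether a smaller sulfonyl group such as methyl, or an unsubstituted phenyl, would follow the same pattern. On these data alone, a longer chain to the amine, or a cyclic amine such as morpholine in place of dimethylamino, also remains open.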